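A few compounds are considered here, and "the series" means these few. Any claim that something is new, unique, unknown or untested is made for them only; others in the source may bear on it.

Compound 1 `O=C(CCCCc1ccccc1)CC(=O)N[C@H]1CCOC1=O` and compound 2 `O=C(CCCCCc1ccccc1)CC(=O)N[C@H]1CCOC1=O` share one core, while compound 3 `O=C(CCCCCCCCCCc1ccccc1)N[C@H]1CCOC1=O` and compound 4 `O=C(CCCCCCCCCCCc1ccccc1)N[C@H]1CCOC1=O` share another; the difference between the two cores is not broken down here. In a functional assay on NCI-H630 cells (Homo sapiens) for cytotoxicity, read by sulforhodamine B assay, with a stated time of 5 days (a higher number here means a weaker inhibitor, a lower number a stronger inhibitor), compound 1 gives > 100000 nM, which is a limit of the assay and not a number, namely (the limit of > 100000 nM in this assay, at which 1 of the 3 values shown sits). In this assay compound 2 gives 44000 nM, and compound 3 gives 70000 nM. The change from compound 1 to compound 2 is benzyl in place of phenyl on a saturated chain carbon, four bonds along the chain from a carbonyl carbon, and it made a step of an at least 2.2-fold lower number from compound 1 to compound 2 (0.35 log units; beyond the scatter). From compound 3 to compound 4 the change is benzyl in place of phenyl on a saturated chain carbon, ten or more bonds along the chain from a carbonyl carbon: the same kind of change as the earlier one, set at a different place on the chain. A similar, modest step is expected, resting on the earlier one, an at least 2.2-fold lower number from compound 1 to compound 2 (0.35 log units; beyond the scatter). The step expected here is a 1.8-fold lower number from compound 3 to compound 4 (0.24 log units; within the scatter). Compound 4 is therefore estimated at 40000 nM, likely between 18000 nM and 90000 nM.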

Compound 4, half-maximal inhibitory concentration: > 100000 nM
Compound 4: a limit, no number; the forecaster's own chance of this, stated with the estimate: 15%; middle value at least 2.5-fold (0.39 log units) from the limit.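

In this assay the change from phenyl to benzyl gives an at least 1.4-fold higher number from compound 3 to compound 4 (0.15 log units; that floor lies within the scatter), and the value of compound 4 is a limit of the assay and not a number: the limit of > 100000 nM in this assay, at which 2 of the 4 values shown sit.

The same change did not carry over unchanged from the core of compound 1 to the core of compound 3: the same change on two cores in this assay, an at least 2.2-fold lower number (0.35 log units; beyond the scatter) from compound 1 to compound 2 and an at least 1.4-fold higher number (0.15 log units; that floor lies within the scatter) from compound 3 to compound 4, at least 3.2-fold (0.51 log units) apart, beyond the scatter of two such steps

From the compounds shown here alone, a step on one of these cores is thus a poor guide to the step on the other, but both steps rest on limits, so their true sizes remain unknown, and one pair per core cannot show what sets them apart.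

Still open, going by these compounds, is whether phenethyl at the chain end would also part the two cores in this assay. A carboxylic acid or an amine at that chain end is also an open case.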